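This account rests on a few compounds, and the source may have more. Where it says the series, first, only, none or still open, it means among the compounds named here.

Going by the values given here, in a functional assay on CCRF-CEM cells (Homo sapiens) for antiproliferative activity (a higher number here means a weaker inhibitor, a lower number a stronger inhibitor), compound 1 `COc1cc(C(=O)c2sc(-c3ccccc3)cc2N)cc(OC)c1OC` gives 4.5 nM and compound 2 `COc1cc(C(=O)c2sc(-c3ccc(Cl)c(Cl)c3)cc2N)cc(OC)c1OC` gives 290 nM, the higher of the two numbers so far. Compound 3 `COc1cc(C(=O)c2sc(-c3ccc(C(F)(F)F)cc3)cc2N)cc(OC)c1OC` differs from compound 2 as follows: 4-(trifluoromethyl)phenyl in place of 3,4-dichlorophenyl on an aromatic carbon. The swap, 4-(trifluoromethyl)phenyl in place of 3,4-dichlorophenyl, lies on an aromatic carbon next to the ring sulfur. Among the compounds with values here, one measured step bears on it: a 64-fold higher number from compound 1 to compound 2 (1.81 log units; beyond the scatter), a large step at the same carbon, with 3,4-dichlorophenyl in place of phenyl. That single step does not separate the contributions of the two chlorines. Compound 3 still carries a substituted phenyl, unlike compound 1 at 4.5 nM, so a full return to that number is not expected. On these data alone, a moderate step towards a lower number in this assay is expected, though the opposite direction remains open. The estimated change is a 2.4-fold lower number from compound 2 to compound 3 (0.38 log units; beyond the scatter). For compound 3 the expected value is 120 nM, with an estimated range of 15 nM to 800 nM.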

Compound 3, half-maximal inhibitory concentration: 270 nM
Compound 3: middle estimate off by 2.3-fold (0.35 log units), on the low side, and the stated range covers the measured number.
By their numbers in this assay, from the lowest: compound 1; then compounds 3 and 2 (each within the scatter of the next).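

Working from this assay, replacing 3,4-dichlorophenyl with 4-(trifluoromethyl)phenyl on this aromatic carbon gives a 1.1-fold lower number from compound 2 to compound 3 (0.03 log units; within the scatter), so the two substituted phenyl groups cannot be told apart here despite their different substituents and heavy-atom counts. A single trifluoromethyl on the phenyl of compound 1 gives a 60-fold higher number from compound 1 to compound 3 (1.78 log units; beyond the scatter), so the large loss at this position does not require two chlorines and is not confined to chlorine substitution. No evidence at hand accounts for either step.

The compounds shown leave open whether a smaller substituent on the phenyl, such as a single fluorine or a methyl, would retain the number of compound 1. They also leave open how a methoxy group or an amine on the phenyl would behave at this position.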